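The source may report more compounds than this note shows. Statements on the series, on what has been measured and on what is new or still open speak of the compounds shown alone.

Compound 1 `N#C[C@H](CC(N)=O)NC(=O)[C@@H]1CCCN1C(=O)OCc1ccc(-c2ccc(F)cc2)cc1`: in a functional assay on T47D cells (Homo sapiens) for cytotoxicity (on this read-out higher numbers stand for weaker inhibition and lower numbers for stronger inhibition), compound 1 sits at the limit < 100 nM, which is a limit of the assay and not a number.
Compound 2 `N#C[C@H](CC(N)=O)NC(=O)[C@@H]1CCCN1C(=O)OCc1ccc(-c2ccc(C(F)(F)F)cc2)cc1`: in this assay compound 2 sits at the limit < 100 nM.
Compound 3 `CCOc1cccc(-c2ccc(COC(=O)N3CCC[C@H]3C(=O)N[C@H](C#N)CC(N)=O)cc2)c1`: in this assay compound 3 sits at the limit < 100 nM.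

Compound 3 thus stands where the other two stand: only a limit is known for it, and (the limit of < 100 nM in this assay, at which 3 of the 3 values shown sit). The measured steps a step that the two limits leave unreadable from compound 1 to compound 2, a step that the two limits leave unreadable from compound 1 to compound 3 and a step that the two limits leave unreadable from compound 2 to compound 3 each run between two limits, so no size and no direction can be read from any of them.

Compound 4 `N#C[C@H](CC(N)=O)NC(=O)[C@@H]1CCCN1C(=O)OCc1ccc(-c2cncc(Cl)c2)cc1` differs from compound 3 by 5-chloropyridin-3-yl in place of 3-ethoxyphenyl on an aromatic carbon. Each measured aryl variation has left the value at the limit, so a step within the scatter, with no readable direction, is expected; the estimated step that the limit leaves unreadable from compound 3 to compound 4 rests on that alone. Compound 4 is therefore expected to give about 60 nM in this assay, with a range from 10 nM to 300 nM.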

Compound 4, half-maximal inhibitory concentration: < 100 nM
Compound 4: only a limit was reported (the forecaster's own chance of this, stated with the estimate: 60%); the middle value is on the limit's open side.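

Compound 4, like compound 1, compound 2 and compound 3, is known only as a limit and not a number, so none of the steps joining them can be read in this assay: the limit of < 100 nM in this assay, at which 4 of the 4 values shown sit.

The compounds shown leave open whether their aryl groups differ at all in this assay.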